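Methoxy in place of bromo: compound 2 to compound 3

The source may report more compounds than this note shows. Statements on the series, on what has been measured and on what is new or still open speak of the compounds shown alone.

Measured so far:
- compound 1 `CC(C)(C)c1cc(NC(=O)Nc2ccc(-c3cc4ccccc4s3)cc2)no1`: > 900 nM
- compound 2 `CC(C)(C)c1cc(NC(=O)Nc2ccc(-c3cn4ccc(Br)cc4n3)cc2)no1`: 9.59 nM

In a functional assay on MV4-11 cells (Homo sapiens) for cytotoxicity, read by MTT assay, with a stated time of 72 h (on this read-out lower numbers stand for stronger inhibition and higher numbers for weaker inhibition), compound 1 gives > 900 nM; this is a limit of the assay and not a number (the limit of > 900 nM in this assay, at which 1 of the 2 values shown sits). Within the data shown here, compound 2 gives 9.59 nM in this assay, and it is the only numeric value shown. Among the measured compounds shown here, no step between two measured compounds differing in a single place exists in this set, so nothing measured tells how a change on the ring bearing the bromo plays out.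

Compound 3 `COc1ccn2cc(-c3ccc(NC(=O)Nc4cc(C(C)(C)C)on4)cc3)nc2c1` is the next compound. It differs from compound 2 by methoxy in place of bromo on an aromatic carbon. The change is small in size and leaves the shared core of compound 2 untouched, and no measured evidence points either way for its direction. The expectation is therefore a step in this assay of a 1.6-fold higher number from compound 2 to compound 3 (0.19 log units; within the scatter), that is none beyond the usual scatter. For compound 3 the estimate in this assay is 15 nM, expected to lie between 5 nM and 45 nM.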

Compound 3, half-maximal inhibitory concentration: 2.84 nM
Beside the measured number, compound 3's estimate is 5.3-fold (0.72 log units) above it; measured number below the stated range.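

In this assay, the series now has a step between two compounds that differ in one place, and it reads a 3.4-fold lower number from compound 2 to compound 3 (0.53 log units; beyond the scatter), with compound 3 at 2.84 nM as the stronger inhibitor of the pair. Among these compounds, the carbon opposite the ring nitrogen therefore does not depend on bromo for activity on this read-out: methoxy, with 2 heavy atoms and 1 hydrogen-bond acceptor where bromo has 1 heavy atom and none, is accepted there and shifts the number beyond the usual scatter, something the earlier compounds could not show. No measurement shown bears on why this exchange moves the number in this direction.

Open, as far as these compounds go, is whether the gain belongs to methoxy itself or would also appear with an amine, a hydroxyl or a longer chain such as ethoxy on the same carbon, with the shared core unchanged. Also open, from the compounds shown here alone, is whether the same exchange would give a step of this size and direction on another carbon of that ring, as one step at one place sets no pattern for the series.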